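Changing the Side Chain on a Shared Nucleoside Core

This account rests on a few compounds, and the source may have more. Where it says the series, first, only, none or still open, it means among the compounds named here.

Measured compounds:
compound 1, `CN(C)CCCn1c(=O)n(C2OC(CO)[C@@H](O)[C@H]2O)c2nc(N)nc(O)c21`, 83%
compound 2, `NC(=O)Cn1c(=O)n(C2OC(CO)[C@@H](O)[C@H]2O)c2nc(N)nc(O)c21`, 32%

In a functional assay on the whole organism (B cells) with Mus musculus as the target (a lower number here means a smaller maximal response, a higher number a larger maximal response), compound 1 reaches 83%, while compound 2 reaches 32%, the lower of the two numbers. Among the compounds with values here, the one measured step, a number 51 percentage points lower from compound 1 to compound 2 (beyond the scatter), shows that exchanging the 2-(dimethylamino)ethyl group for a carbamoyl group on the saturated chain carbon bound to the aromatic nitrogen cut the maximal response sharply.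

Compound 3, `NCC(O)Cn1c(=O)n(C2OC(CO)[C@@H](O)[C@H]2O)c2nc(N)nc(O)c21`, is not yet measured. It differs from compound 2 by 2-amino-1-hydroxyethyl in place of carbamoyl on a saturated chain carbon bound to an aromatic nitrogen. The new group brings back a chain with a nitrogen, as compound 1 has, although here it is accompanied by a hydroxyl and is shorter than the chain in compound 1.

Within the data shown here, only the step from compound 1 to compound 2 bears on this change, and it was large. Because a number 51 percentage points lower from compound 1 to compound 2 (beyond the scatter), a chain with an amine appears to carry a larger response than the carbamoyl, so a rise is expected for compound 3, though the amino alcohol is not the same as the dimethylamino chain, which leaves the size uncertain. Compound 3 is therefore estimated at 60%, within 35% to 85%, an expected step of a number 28 percentage points higher from compound 2 to compound 3 (beyond the scatter).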

Compound 3, largest response reached (reported as maximal response), in percent of the reference or control that the assay uses: 110%
Estimate against measurement, compound 3: 50 percentage points below; measured number above the stated range.
By their numbers in this assay, from the lowest: compound 2; then compound 1; then compound 3.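

In this assay, exchanging carbamoyl for 2-amino-1-hydroxyethyl on the saturated chain carbon bound to the aromatic nitrogen gives a number 78 percentage points higher from compound 2 to compound 3 (beyond the scatter). The change from 2-(dimethylamino)ethyl to the same group gives a number 27 percentage points higher from compound 1 to compound 3 (beyond the scatter), so compound 3 stands highest of the three and the earlier response of compound 1 was not the ceiling at this position. Both groups that carry a nitrogen amine stand above carbamoyl, yet they differ clearly from each other, so having an amine in the chain does not alone set the size of the response in these three compounds. Nothing shown here explains the gain of compound 3 over the others.

The new group differs from 2-(dimethylamino)ethyl in more than one feature, so the hydroxyl and the unsubstituted amine cannot be told apart as the source of the rise. A 2-aminoethyl group, with the amine but no hydroxyl, and a 2-hydroxyethyl group, with the hydroxyl but no amine, would each separate one feature from the other at this position.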